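The compounds below may be only part of what the source reports. "The series", "measured", "known", "first", "only" and "open" are said of these compounds alone.

Of the compounds shown here, two have been measured so far. Compound 1 `O=C(/C=C/c1ccc(CN2C(=O)/C(=C3\Nc4ccccc4\C3=N/O)c3cc(Br)ccc32)cc1)NO` gives, in a functional assay on PC-3 cells (Homo sapiens) for cytotoxicity, read by colorimetric assay (on this read-out lower numbers stand for stronger inhibition and higher numbers for weaker inhibition), 90 nM. Compound 2 `O=C(/C=C/c1ccc(CN2C(=O)/C(=C3\Nc4ccccc4\C3=N/O)c3cc(Cl)ccc32)cc1)NO` gives, in this assay, 60 nM. Within the data shown here, the one step between them, a 1.5-fold lower number from compound 1 to compound 2 (0.18 log units; within the scatter), puts the two within the scatter of each other, so neither can be called the more active on this evidence. Compound 2 holds the lower of the two numbers, and its nearest neighbour is compound 1.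

The next compound, compound 3 `O=C(/C=C/c1ccc(CN2C(=O)/C(=C3\Nc4ccccc4\C3=N/O)c3ccccc32)cc1)NO`, differs from compound 2 by a single change: hydrogen in place of chloro on an aromatic carbon. Among the measured compounds shown here, the only measured step that bears on this change is the exchange of one halogen for another between compound 1 and compound 2, which moved the number by a 1.5-fold lower number from compound 1 to compound 2 (0.18 log units; within the scatter). For the measured compounds named here, there is no measured step in which the halogen is removed altogether, so the expectation rests on that one step alone. Compound 3 is therefore expected to land near compound 2, with at most a modest step; the estimate is 100 nM with a range from 40 nM to 250 nM, corresponding to an expected step of a 1.7-fold higher number from compound 2 to compound 3 (0.22 log units; within the scatter) in this assay.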

Compound 3, half-maximal inhibitory concentration: 50 nM
The estimate for compound 3 lay 2.0-fold (0.30 log units) above the measured number, within the range that was stated.
By their numbers in this assay, from the lowest: compounds 3, 2 and 1 (each within the scatter of the next).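

Among these compounds, until now this position had been seen only with one halogen exchanged for another, and compound 3 shows it with no halogen at all. In this assay hydrogen in place of chloro gives a 1.2-fold lower number from compound 2 to compound 3 (0.08 log units; within the scatter) and hydrogen in place of bromo gives a 1.8-fold lower number from compound 1 to compound 3 (0.26 log units; within the scatter) and so, on the evidence of these three compounds, neither chloro nor bromo on this aromatic carbon separates a compound from the one bearing hydrogen. No measurement at hand offers an explanation for this result.

On these data alone, whether a methoxy group, an amine or a carboxylic acid on the same aromatic carbon would stay within the scatter of these three compounds remains open, as does whether any group here can produce a step beyond it. Since the three compounds share everything else, they also leave open how changes elsewhere on the shared core, such as at the oxime or the hydroxamic acid, would read in this assay and whether the picture at this position would hold there.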